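From tert-butyl to amino in the series

The compounds below may be only part of what the source reports. "The series", "measured", "known", "first", "only" and "open" are said of these compounds alone.

In a physicochemical assay for lipophilicity, read by HPLC, measured as octanol-water partition (on this read-out higher numbers stand for higher lipophilicity and lower numbers for lower lipophilicity), compound 3 (`CC(C)(C)c1ccc(C(=O)N/N=C/c2ccc3no[n+]([O-])c3c2)cc1`) stands highest at 3.8, with compound 1 (`O=C(N/N=C/c1ccc2no[n+]([O-])c2c1)c1ccccc1`) at 2.2 and compound 2 (`O=C(N/N=C/c1ccc2no[n+]([O-])c2c1)c1ccccc1O`) at 1.3. Compound 4 (`Nc1ccc(C(=O)N/N=C/c2ccc3no[n+]([O-])c3c2)cc1`) carries amino in place of tert-butyl on an aromatic carbon, para to a large group: amino in place of tert-butyl on an aromatic carbon. Among the measured compounds shown here, two measured steps bear on this change. Tert-butyl in place of hydrogen gave a number 1.60 log units higher from compound 1 to compound 3 (beyond the scatter), and the new structure gives that group up. Hydroxy in place of hydrogen gave a number 0.90 log units lower from compound 1 to compound 2 (beyond the scatter), which serves as the closest available guide, since no amino compound has been measured. Taken together, these two steps point to a large fall in this assay. The expected step is a number 2.40 log units lower from compound 3 to compound 4 (beyond the scatter). For compound 4 the estimated value is 1.4, with an expected range of 0.9 to 1.9.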

Compound 4, partition coefficient: 1.2
Estimate against measurement, compound 4: 0.20 log units above; measured number inside the range.
By their numbers in this assay, from the lowest: compounds 4 and 2 (each within the scatter of the next); then compound 1; then compound 3.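

Amino in place of hydrogen gives a number 1.00 log units lower from compound 1 to compound 4 (beyond the scatter) in this assay, and amino in place of tert-butyl at this same place gives a number 2.60 log units lower from compound 3 to compound 4 (beyond the scatter) on that read-out. The hydroxy result is now joined by a second group that lowers the number relative to compound 1, although the two groups stand at different places on the aromatic ring. The exchange of 2-hydroxyphenyl for 4-aminophenyl gives a number 0.10 log units lower from compound 2 to compound 4 (within the scatter) and leaves those two compounds unseparated.

Still open, from the compounds shown here alone, is how a methoxy group or a carboxylic acid would read at this place, and how hydroxy would read there. No measurement available here accounts for these steps.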